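A few compounds are considered here, and "the series" means these few. Any claim that something is new, unique, unknown or untested is made for them only; others in the source may bear on it.

In a functional assay on MDBK cells (Bos taurus) for cytotoxicity (a lower number here means that less compound is tolerated, a higher number that more compound is tolerated), compound 3 `C=CCO/N=C(\C#N)C(=O)NCC1=NOC(C(C)(C)C)C1` gives > 100 ug/mL, which is a limit and not a number. Compound 2 `CC(C)O/N=C(\C#N)C(=O)NCC1=NOC(C(C)(C)C)C1` gives > 100 ug/mL, also a limit. Within the data shown here, compound 1 `C=CCO/N=C(\C#N)C(=O)NCC1=NOC(c2ccccc2)C1` gives 100 ug/mL, the only readable number in the set. Compound 3 therefore stands at the limit of > 100 ug/mL in this assay, at which 2 of the 3 values shown sit.

The change to compound 4 `CC(C)(C)C1CC(CNC(=O)/C(C#N)=N/OCc2ccccc2)=NO1` is phenyl in place of vinyl on a saturated chain carbon bound to an oxygen on an unsaturated carbon; cut one bond further out, it reads allyl to benzyl. The step at the same oxygen, a step that the two limits leave unreadable from compound 2 to compound 3, gives no size to carry over. As far as these compounds go, the other measured step, a number no lower from compound 1 to compound 3 (the limit leaves the size open), is tert-butyl in place of phenyl on a saturated ring carbon, and its size also stays open. Neither step supports a firm shift in this assay. A modest move toward a lower number remains possible, as phenyl-bearing compound 1 has a readable 100 ug/mL.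

The expected change is a number no higher from compound 3 to compound 4 (the limit leaves the size open), which may not exceed the scatter. For compound 4 the estimate is 100 ug/mL, with an expected range of 40 ug/mL to 200 ug/mL.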

Compound 4, half-maximal cytotoxic concentration: 100 ug/mL
For compound 4 middle estimate and measured number coincide at the digits printed; low and high end bracket the measured number.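

In this assay compound 4 gives 100 ug/mL as the first readable number among the compounds shown with tert-butyl on the saturated ring carbon. Compound 3 gives > 100 ug/mL as a limit and not a number. With tert-butyl held, benzyl on the oxygen gives a value that can be read, whereas allyl and isopropyl give only limits. Benzyl in place of allyl on the oxygen gives a number no higher from compound 3 to compound 4 (the limit leaves the size open) and benzyl in place of isopropyl on the oxygen gives a number no higher from compound 2 to compound 4 (the limit leaves the size open) but neither step can be read in size because both starting compounds sit at a limit: the limit of > 100 ug/mL in this assay, at which 2 of the 4 values shown sit.

As far as these compounds go, how far the number would move with a longer chain on the oxygen remains open. So does the reading in this assay with an amine or a carboxylic acid on the benzyl group.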